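A few compounds are considered here, and "the series" means these few. Any claim that something is new, unique, unknown or untested is made for them only; others in the source may bear on it.

Measured so far:
Compound 1 `Nc1cc(N)c2nc(-c3ccccc3)c(Oc3ccc(Cl)c(Cl)c3)nc2c1`: 4070 nM
Compound 2 `CCOC(=O)[C@H](CCC(=O)O)NC(=O)c1ccc(Sc2nc3cc(N)cc(N)c3nc2-c2ccccc2)cc1`: 28200 nM
Compound 3 `COc1cc(CNc2nc3cc(N)cc(N)c3nc2-c2ccccc2)cc(OC)c1OC`: 11200 nM

In a functional assay on UO-31 cells (Homo sapiens) for inhibition, read by sulforhodamine B assay, with a stated time of 48 h (a higher number here means a weaker inhibitor of growth, a lower number a stronger inhibitor of growth), compound 1 gives the lowest number of the three, with compound 3 nearest and compound 2 furthest away, both gaps beyond the scatter. Compound 4 `Nc1cc(N)c2nc(-c3ccccc3)c(Sc3ccc(F)cc3)nc2c1` has not yet been tested; it differs from compound 1 by (4-fluorophenyl)sulfanyl in place of 3,4-dichlorophenoxy on an aromatic carbon. Among the compounds with values here, no pair that differs in one place has been measured, so the effect of this change cannot be read from the data. Compound 4 is expected to stay close to compound 1, with the step estimated as a 1.5-fold higher number from compound 1 to compound 4 (0.17 log units; within the scatter), a slight loss at most. The estimate for compound 4 in this assay is 6000 nM, within a range of 2000 nM to 18000 nM.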

Compound 4, concentration for 50% growth inhibition: < 100000 nM
Compound 4: a limit, no number; the forecaster's own chance of this, stated with the estimate: 5%; the middle value does not contradict the limit.
By their numbers in this assay, from the lowest: compound 1; then compound 3; then compound 2.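

In this assay, within the data shown here, compound 4 gives < 100000 nM, which is a limit and not a number, so no step from compound 1 to compound 4 can be read. The compounds shown leave open how (4-fluorophenyl)sulfanyl in place of 3,4-dichlorophenoxy changes growth inhibition.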